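Fluoro-to-chloro swaps in a cytotoxic series

The compounds below may be only part of what the source reports. "The series", "measured", "known", "first", "only" and "open" are said of these compounds alone.

In a functional assay on T29Kt1 cells (Homo sapiens) for cytotoxicity, read by sulforhodamine B assay, with a stated time of 3 days (on this read-out lower numbers stand for stronger inhibition and higher numbers for weaker inhibition), compound 1 `OCc1cn(Cc2cccc(F)c2)c2ccccc12` gives 20 nM. Compound 2 `OCc1cn(Cc2cccc(Cl)c2)c2ccccc12` carries the change chloro in place of fluoro on an aromatic carbon and in this assay compound 2 gives 160 nM; the step is an 8.0-fold higher number from compound 1 to compound 2 (0.90 log units; beyond the scatter). Compound 3 `OCc1cn(Cc2ccc(Cl)cc2)c2ccc(F)cc12` in this assay gives 80 nM. The difference between the core of compound 1 and the core of compound 3 is not broken down here. The values of compound 3 and compound 2 lie within the scatter of each other, while compound 3 stands beyond the scatter away from compound 1.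

Compound 4 `OCc1cn(Cc2ccc(Cl)cc2)c2ccc(Cl)cc12` is not yet measured. It differs from compound 3 by chloro in place of fluoro on an aromatic carbon. This is the same kind of change as that from compound 1 to compound 2, not the same one: in the earlier pair the carbon lies on a six-membered aromatic ring of carbon only, meta to a large group, whereas here it lies on a ring that is part of a fused or bridged system of two rings, meta to a fused ring and para to a fused ring. Going by the values given here, the only guide is that the same kind of swap gave an 8.0-fold higher number from compound 1 to compound 2 (0.90 log units; beyond the scatter); the different surroundings make a smaller step the safer expectation. In this assay compound 4 is expected to give 240 nM, between 80 nM and 800 nM, an expected step of a 3.0-fold higher number from compound 3 to compound 4 (0.48 log units; beyond the scatter).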

Compound 4, half-maximal inhibitory concentration: 13000 nM
Estimate against measurement, compound 4: 54-fold (1.73 log units) below; the whole stated range lies below it.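

Chloro in place of fluoro on an aromatic carbon gives a higher number on both cores in this assay, but the size of the step does not carry over from one core to the other: the same change on two cores in this assay, an 8.0-fold higher number (0.90 log units; beyond the scatter) from compound 1 to compound 2 and a 160-fold higher number (2.21 log units; beyond the scatter) from compound 3 to compound 4, 20-fold (1.31 log units) apart, beyond the scatter of two such steps

On the ring that is part of a fused or bridged system of two rings, the swap gives a 160-fold higher number from compound 3 to compound 4 (2.21 log units; beyond the scatter), a large step that places compound 4 well out from the other compounds of this short series. Going by these compounds alone, with only two pairs, which differ both in the ring carrying the swap and in the rest of the core, the data do not show whether the place of the halogen or the surrounding core sets the size of the step, and they give no rule for a third core.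

Going by these compounds, it remains open how a bromo, methoxy or nitrile group on the same aromatic carbon would read in this assay. Also open, on these data alone, is whether the step would persist with an amine or a carboxylic acid in place of the hydroxymethyl group.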